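The source may report more compounds than this note shows. Statements on the series, on what has been measured and on what is new or still open speak of the compounds shown alone.

Compound 1 `Fc1ccccc1Cc1nc(-c2nc(C(F)(F)F)n[nH]2)c2cccnn12` gives "not determined" (no result reported)
Compound 2 `Fc1ccccc1Cc1nc(-c2nc(C(F)(F)F)n[nH]2)n2cccnc12` gives 17 mL.min-1.g-1
Compound 3 `Fc1ccccc1Cc1nc(-c2nc(Cc3ccccc3)n[nH]2)n2ccccc12` gives "not determined" (no result reported)

In an in vitro ADME assay on microsomes from liver (Homo sapiens) for metabolic stability (a higher number here means faster removal of the compound, a lower number slower removal), only one of these compounds has a number. Compound 3 stands without a single value ("not determined" (no result reported)), and compound 1 is in the same position, so the starting point of the step cannot be placed on the scale. The step leads to compound 4 `Fc1ccccc1Cc1nc(-c2ncn[nH]2)n2ccccc12` and puts hydrogen in place of benzyl on an aromatic carbon. Among the measured compounds shown here, no measured pair shows what such a change does in this assay, so neither its size nor its direction can be read from the data. For the measured compounds named here, the only anchor is compound 2 (17 mL.min-1.g-1), and no difference from that level beyond the usual scatter is expected, with no firm direction. The expected intrinsic clearance of compound 4 is 14 mL.min-1.g-1 within an estimated range from 6 mL.min-1.g-1 to 32 mL.min-1.g-1 once it has been measured.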

Compound 4, intrinsic clearance in microsomes: 175 mL.min-1.g-1
Beside the measured number, compound 4's estimate is 13-fold (1.10 log units) below it; the measured number lies above the stated range.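

Among the compounds shown here, compound 3 has no single value, so no step to compound 4 can be read, and in this assay compound 4 gives 175 mL.min-1.g-1 on its own. No evidence at hand bears on this result. The compounds shown leave open what hydrogen in place of benzyl does to intrinsic clearance in microsomes.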